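This account rests on a few compounds, and the source may have more. Where it says the series, first, only, none or still open, it means among the compounds named here.

Measured so far:
- Compound 1 `COc1cc(OC)cc(N2CCN(c3nc(=O)c4cc(C(F)(F)F)cc([N+](=O)[O-])c4s3)CC2)c1`: > 101000 nM (a limit)
- Compound 2 `O=c1nc(N2CCN(Cc3ccncc3)CC2)sc2c([N+](=O)[O-])cc(C(F)(F)F)cc12`: > 111000 nM (a limit)

Both entries come from a toxicity assay on HeLa cells (Homo sapiens) for cytotoxicity, read by colorimetric assay, with a stated time of 72 h; a lower number here means that less compound is tolerated, a higher number that more compound is tolerated. Compound 2 stands at > 111000 nM, which is a limit and not a number. Compound 3 `O=C(CN1CCN(c2nc(=O)c3cc(C(F)(F)F)cc([N+](=O)[O-])c3s2)CC1)Nc1ccccn1` carries (pyridin-2-yl)carbamoyl in place of pyridin-4-yl on a saturated chain carbon bound to an amine nitrogen in a ring. Among the measured compounds shown here, the only measured step bearing on this is a step that the two limits leave unreadable from compound 1 to compound 2, which also changed the group on that ring nitrogen. With so little to go on, no step beyond the scatter is expected in this assay. For compound 3 the estimate is 100000 nM, within a range of 40000 nM to 130000 nM. This estimate means an expected at least 1.1-fold lower number from compound 2 to compound 3 (0.04 log units; that floor lies within the scatter).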

Compound 3, half-maximal cytotoxic concentration: 44500 nM
Estimate against measurement, compound 3: 2.2-fold (0.35 log units) above; low and high end bracket the measured number.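

In this assay, among the compounds shown here, compound 3 is the first compound here to give a number and not a limit, so the change on this chain carbon can now be read in part, as an at least 2.4-fold lower number from compound 2 to compound 3 (0.39 log units; beyond the scatter). The change on the ring nitrogen gives an at least 2.2-fold lower number from compound 1 to compound 3 (0.35 log units; beyond the scatter), whereas the step between the two limits cannot be read. These steps are only minimum sizes because the starting compound stands at a limit, for compound 2: the limit of > 111000 nM in this assay, at which 1 of the 3 values shown sits.

The compounds shown leave open whether the carbonyl and amide hydrogen or the pyridin-2-yl ring accounts for the lower number. They also leave open what a plain phenyl amide or a longer chain would give.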